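Replacing the thiophene on the chain carbon with a hydroxybutyl group

A few compounds are considered here, and "the series" means these few. Any claim that something is new, unique, unknown or untested is made for them only; others in the source may bear on it.

Within the data shown here, compound 2 `O=C(O)COc1cccc(CC(c2nc(-c3ccccc3)c(-c3ccccc3)o2)c2cccs2)c1` gives 33200 nM in a functional assay for inhibition, with Homo sapiens as the target (on this read-out higher numbers stand for weaker inhibition and lower numbers for stronger inhibition), the highest of the two numbers available; its nearest neighbour, compound 1 `C[S+]([O-])C(Cc1cccc(OCC(=O)O)c1)c1nc(-c2ccccc2)c(-c2ccccc2)o1`, gives 7080 nM, and the change a 4.7-fold higher number from compound 1 to compound 2 (0.67 log units; beyond the scatter) is the only measured step. Compound 3 `O=C(O)COc1cccc(CC(CCCCO)c2nc(-c3ccccc3)c(-c3ccccc3)o2)c1` has not been measured; it differs from compound 2 by 4-hydroxybutyl in place of thiophen-2-yl on a saturated chain carbon bound to an aromatic carbon and a saturated chain carbon. This change touches the same saturated chain carbon that the measured step altered, where a group with no ring was exchanged for thiophen-2-yl and the number rose. Compound 3 reverses that exchange in kind, putting a group with no ring, 4-hydroxybutyl, back at this place, so a step of similar size in the opposite direction, toward a lower number, is the expectation for a 3.3-fold lower number from compound 2 to compound 3 (0.52 log units; beyond the scatter). Compound 3 is therefore estimated at 10000 nM, with a range from 3000 nM to 33000 nM in this assay.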

Compound 3, half-maximal inhibitory concentration: 4680 nM
Estimate against measurement, compound 3: 2.1-fold (0.33 log units) above; the range from low to high includes it.
By their numbers in this assay, from the lowest: compounds 3 and 1 (each within the scatter of the next); then compound 2.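

The exchange at this saturated chain carbon gives the largest step seen so far in this assay (a 7.1-fold lower number from compound 2 to compound 3 (0.85 log units; beyond the scatter)), and it comes with the same count of heavy atoms entering as leaving, so group size in atoms alone does not separate these two groups. The two ring-free groups cannot be told apart (a 1.5-fold lower number from compound 1 to compound 3 (0.18 log units; within the scatter)), even though they differ in size and atoms; among these three compounds, only the one carrying thiophen-2-yl stands apart, with the weakest inhibition. Nothing available explains this difference.

With thiophen-2-yl the only ring tested here, the compounds shown cannot say whether a phenyl ring would behave the same way. Also open, on these data alone, is whether a plain butyl chain, a longer chain, or an amine or carboxylic acid in place of the hydroxyl would match 4-hydroxybutyl.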